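Carbamoyl Replacing 3-methylbut-2-en-1-yl on the Aromatic Oxygen

The source may hold more compounds than are shown below. What is called first, only, known or untested is meant among the compounds shown, and "the series" means these compounds.

Compound 1 `CC(C)=CCOc1cc(=O)n(CCCO)c2c1CC(CC=C(C)C)C(C)(C)C2`: 7.5%
Compound 2 `CC(C)=CCC/C(C)=C/CC1Cc2c(OCC=C(C)C)cc(=O)n(CCCO)c2CC1(C)C`: 15.9%
Compound 3 `CC(C)=CCC/C(C)=C/CC1Cc2c(OCCCOc3ccc([N+](=O)[O-])cc3)cc(=O)n(CCCO)c2CC1(C)C`: 9.8%

In a functional assay on PANC-1 cells (Homo sapiens) for inhibition, read by MTT assay, with a stated time of 24 h, tested at 10 uM (on this read-out lower numbers stand for less inhibition and higher numbers for more inhibition at the one concentration tested (going by the name of the read-out)), compound 2 holds the highest of the three numbers, yet both of its neighbours sit within the scatter of it: a number 8.4 percentage points higher from compound 1 to compound 2 (within the scatter) and a number 6.1 percentage points lower from compound 2 to compound 3 (within the scatter). Compound 4 `COc1ccc(NC(=O)Oc2cc(=O)n(CCCO)c3c2CC(C/C=C(\C)CCC=C(C)C)C(C)(C)C3)cc1` differs from compound 2 in one place: (4-methoxyphenyl)carbamoyl in place of 3-methylbut-2-en-1-yl on an oxygen on an aromatic ring. Within the data shown here, only the step from compound 2 to compound 3 touches the same oxygen on the aromatic ring, and that exchange stayed within the scatter; no measured step brings in a carbamoyl group, so its effect is unknown. Compound 4 is therefore expected to show no step beyond the scatter in this assay, a number 3.9 percentage points lower from compound 2 to compound 4 (within the scatter). The estimate for compound 4 is 12%, with a range from 2% to 26%.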

Compound 4, a percentage reported as inhibition, at one concentration (the size of the read-out at that concentration, not a potency): 0%
For compound 4 the middle estimate is 12 percentage points above the measured one; measured number outside the range, below it.
By their numbers in this assay, from the lowest: compounds 4, 1, 3 and 2 (each within the scatter of the next, the first and the last beyond it).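

Among these compounds, at the oxygen on an aromatic ring, (4-methoxyphenyl)carbamoyl in place of 3-methylbut-2-en-1-yl gives the first step beyond the scatter in this assay, a number 15.9 percentage points lower from compound 2 to compound 4 (beyond the scatter). The earlier exchange on this oxygen, a number 6.1 percentage points lower from compound 2 to compound 3 (within the scatter), did not show that this position can move the read-out. Nothing on hand accounts for the difference. The compounds shown leave open whether the step belongs to the carbamoyl link or to its 4-methoxyphenyl end, and how a methylcarbamoyl group or a plain phenylcarbamoyl group on the same oxygen would read.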